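The source may hold more compounds than are shown below. What is called first, only, known or untested is meant among the compounds shown, and "the series" means these compounds.

In a functional assay on the whole organism (strain Swiss) with Mus musculus as the target, in the maximal electroshock model, with a stated time of 0.25 h, at a dose of 300 mg/kg by the intraperitoneal route (a higher number here means a stronger effect of the compound at the dose given, a lower number a weaker effect), compound 1, `CC(C(=O)N1CCN(c2ccccc2)CC1)N1C(=O)CCC1=O`, gives 100%, and compound 2, `CCC(C(=O)N1CCN(c2cccc(F)c2)CC1)N1C(=O)CCC1=O`, gives 75%. On these two numbers compound 2 stands lowest: its nearest neighbour is compound 1, a number higher by a margin that lies beyond the usual scatter of such measurements. Among the measured compounds shown here, compound 2 and compound 1 differ in two places at once, so no single step between them can be read from the data.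

Compound 3, `CC(C(=O)N1CCN(c2cccc(F)c2)CC1)N1C(=O)CCC1=O`, differs from compound 2 in one place only: hydrogen in place of methyl on a saturated chain carbon, two bonds along the chain from an amide-type nitrogen in a ring and a carbonyl carbon. For the measured compounds named here, no measured pair shows this change by itself, so the expected size of the step rests on the two values alone; the estimate for the step from compound 2 to compound 3 is a number 15 percentage points higher from compound 2 to compound 3 (beyond the scatter), an upward movement of modest size in this assay. In this assay compound 3 is therefore expected to give 90%, with a range from 65% to 100%.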

Compound 3, a percentage reported as activity, at one dose (the size of the read-out at that dose, not a potency): 100%
Compound 3: the middle estimate sits 10 percentage points below what was measured; low and high end bracket the measured number.
By their numbers in this assay, from the lowest: compound 2; then compounds 1 and 3 (each within the scatter of the next).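

In this assay, the change from ethyl to methyl on the saturated chain carbon, two bonds along the chain from an amide-type nitrogen in a ring and a carbonyl carbon, gives a number 25 percentage points higher from compound 2 to compound 3 (beyond the scatter), so with the fluoro group kept in place, this position is seen to affect the read-out. Fluoro in place of hydrogen on an aromatic carbon, with the methyl kept in place, gives no change at the digits printed from compound 1 to compound 3 (within the scatter), so this change shows no effect on the read-out at this dose. Nothing available explains why the ethyl to methyl change has this effect.

Going by these compounds, it remains open how a longer chain such as propyl would read at the chain carbon, or how chloro or methoxy would read in place of the fluoro. On these data alone, whether the fluoro change would have the same outcome alongside ethyl also remains open.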